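The compounds below may be only part of what the source reports. "The series", "measured", "known", "first", "only" and "open" are said of these compounds alone.

Measured in a functional assay on HT29-AK cells (Homo sapiens) for cytotoxicity, read by MTT assay, with a stated time of 48 h; on this read-out higher numbers stand for weaker inhibition and lower numbers for stronger inhibition:
compound 1 `Fc1cccc(-c2nc(Nc3ccccc3)c3cc(F)ccc3n2)c1` gives 48300 nM
compound 2 `COc1ccc(Nc2nc(-c3cccc(F)c3)nc3ccc(F)cc23)cc1` gives 42300 nM
compound 3 `Fc1cccc(-c2nc(Nc3ccccc3Cl)c3cc(F)ccc3n2)c1` returns only a limit of this assay, > 50000 nM

Compound 3 thus stands at the ceiling of the numbers shown, where the limit of > 50000 nM in this assay, at which 1 of the 3 values shown sits, applies, and no exact value is known for it. The step of an at least 1.0-fold higher number from compound 1 to compound 3 (0.01 log units; that floor lies within the scatter) and the step of an at least 1.1-fold higher number from compound 2 to compound 3 (0.07 log units; that floor lies within the scatter) are both floors that lie within the scatter, as does a 1.1-fold lower number from compound 1 to compound 2 (0.06 log units; within the scatter); none of the three measured steps moves beyond it.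

Compound 4 `Fc1cccc(-c2nc(Nc3cccc(Br)c3)c3cc(F)ccc3n2)c1` is to be measured in this assay. Against compound 3 the change is 3-bromophenyl in place of 2-chlorophenyl on a nitrogen on an aromatic ring. Of the measured steps, an at least 1.1-fold higher number from compound 2 to compound 3 (0.07 log units; that floor lies within the scatter) and an at least 1.0-fold higher number from compound 1 to compound 3 (0.01 log units; that floor lies within the scatter) bear on this position, and both were flat within the scatter, so no step beyond the scatter is expected for compound 4 in this assay, in either direction. The expected step of a number no higher from compound 3 to compound 4 (the limit leaves the size open) is therefore estimated as essentially none. Compound 4 is estimated at 50000 nM, with a range from 25000 nM to 100000 nM, and a fair chance that this assay again reports only a limit.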

Compound 4, half-maximal inhibitory concentration: > 50000 nM
Compound 4 gave a limit, no number; the forecaster's own chance of this, stated with the estimate: 55%; the middle value sits exactly at the limit.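

In this assay compound 4 returns a limit, as compound 3 does, so 3-bromophenyl on this nitrogen gives no more readable a value than 2-chlorophenyl, and the limit now holds a larger share of the series: the limit of > 50000 nM in this assay, at which 2 of the 4 values shown sit. The step between compound 3 and compound 4 cannot be read, since both values are limits. The two readable comparisons are only floors within the scatter (an at least 1.1-fold higher number from compound 2 to compound 4 (0.07 log units; that floor lies within the scatter) and an at least 1.0-fold higher number from compound 1 to compound 4 (0.01 log units; that floor lies within the scatter)), so the change from the unsubstituted phenyl of compound 1 or the 4-methoxyphenyl of compound 2 to 3-bromophenyl shows no step in either direction.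

From the compounds shown here alone, how far compound 3 and compound 4 actually lie from each other stays open. Also open, going by these compounds, is whether an amine or a carboxylic acid on this phenyl ring would move the number beyond the scatter from compound 1.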